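A few compounds are considered here, and "the series" means these few. Any claim that something is new, unique, unknown or untested is made for them only; others in the source may bear on it.

Measured compounds in this series:

Compound 1 `Cc1cc(=O)oc2c(CN3CCc4ccccc4C3)c(O)ccc12`. In an ADME assay on MT4 cells (Homo sapiens) for cytotoxicity, read by MTT assay, with a stated time of 96 h (a higher number here means that more compound is tolerated, a lower number that less compound is tolerated), compound 1 gives > 100000 nM, which is a limit of the assay and not a number.
Compound 2 `CC(=O)Oc1ccc2ccc(=O)oc2c1Cc1c(-c2ccccc2)[nH]c2ccccc12`. In this assay compound 2 gives > 100000 nM, again a limit of the assay.
Compound 3 `CC(=O)Oc1ccc2c(C)cc(=O)oc2c1Cc1c(-c2ccccc2)[nH]c2ccccc12`. In this assay compound 3 gives > 100000 nM, also a limit of the assay.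

Compound 4 `O=c1ccc2ccc(O)c(CN3CCc4ccccc4C3)c2o1` has not yet been measured in this assay. It differs from compound 1 by one change, (hydrogen in place of methyl on an aromatic carbon). The same change has already been made once within the measured set, from compound 3 to compound 2, described as hydrogen in place of methyl on an aromatic carbon; the two place descriptions agree word for word, so it is the same change in the same surroundings. The measured step for that pair, a step that the two limits leave unreadable from compound 3 to compound 2, cannot be sized, since both ends are limits. How the core of compound 1 differs from the core of compound 3 is not broken down here.

All the evidence available on the step is the limit of > 100000 nM in this assay, at which 3 of the 3 values shown sit; none of the three measured compounds has yet shown a readable cytotoxic concentration within the range covered by the assay.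

For compound 4 the step from compound 1 is expected to be negligible, a step that the limit leaves unreadable from compound 1 to compound 4, and this rests on the limit of > 100000 nM in this assay, at which 3 of the 3 values shown sit, together with the unreadable step that the two limits leave unreadable from compound 3 to compound 2. Compound 4 is therefore expected to come out at 150000 nM, with a plausible range from 60000 nM to 400000 nM, and most likely the assay will again report only a limit.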

Compound 4, half-maximal cytotoxic concentration: > 100000 nM
Compound 4: only a limit was reported (the forecaster's own chance of this, stated with the estimate: 85%); the middle value is on the limit's open side.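

In this assay compound 4 gives > 100000 nM, which is a limit of the assay and not a number. Compound 1 also stands at a limit, so no new step can be read between compound 1 and compound 4. The compounds shown leave open how large the change of hydrogen in place of methyl is and whether any of them reaches a readable half-maximal cytotoxic concentration, as the series stands at a single limit: the limit of > 100000 nM in this assay, at which 4 of the 4 values shown sit.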